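The source may report more compounds than this note shows. Statements on the series, on what has been measured and on what is new or still open speak of the compounds shown alone.

Measured in a functional assay on P388 cells (Mus musculus) for cytotoxicity; on this read-out higher numbers stand for weaker inhibition and lower numbers for stronger inhibition:
- compound 1 `COc1ccc(C[C@H]2C(=O)N[C@@H](C)C(=O)N(C)[C@H]3Cc4ccc(cc4)Oc4cc(ccc4OC)C[C@@H](C(=O)N[C@H](C)C(=O)N[C@@H](CC(=O)O)C(=O)N2C)N(C)C3=O)cc1` gives 1200 nM
- compound 2 `CCCN1C(=O)[C@@H](C)NC(=O)[C@@H]2Cc3ccc(OC)c(c3)Oc3ccc(cc3)C[C@@H](C(=O)N2C)N(C)C(=O)[C@H](C)NC(=O)[C@H](Cc2ccc(OC)cc2)N(C)C(=O)[C@@H]1C` gives 3.98 nM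
- compound 3 `C=CCN1C(=O)[C@@H](C)NC(=O)[C@@H]2Cc3ccc(OC)c(c3)Oc3ccc(cc3)C[C@@H](C(=O)N2C)N(C)C(=O)[C@H](C)NC(=O)[C@H](Cc2ccc(OC)cc2)N(C)C(=O)[C@@H]1C` gives 18.6 nM

Compound 3 (18.6 nM) holds the second highest of these numbers, above compound 2 and well under compound 1. Compound 4 `COc1ccc(C[C@H]2C(=O)N[C@@H](C)C(=O)N(C)[C@H]3Cc4ccc(cc4)Oc4cc(ccc4OC)C[C@@H](C(=O)N[C@H](C)C(=O)N(C/C=C(\C)CCC=C(C)C)[C@@H](C)C(=O)N2C)N(C)C3=O)cc1` is still unmeasured. It differs from compound 3 thus (2,6-dimethylhepta-1,5-dien-1-yl in place of vinyl on a saturated chain carbon bound to an amide-type nitrogen in a ring), with allyl replaced by 3,7-dimethylocta-2,6-dien-1-yl. Among the compounds with values here, one measured step touches this place (a 4.7-fold higher number from compound 2 to compound 3 (0.67 log units; beyond the scatter)), and it is modest and beyond the scatter. No chain of the incoming length has been measured, so the forecast in this assay is loose. A further modest rise is expected (a 3.2-fold higher number from compound 3 to compound 4 (0.51 log units; beyond the scatter)). Compound 4 is estimated at 60 nM with an expected range from 12 nM to 300 nM on this read-out.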

Compound 4, half-maximal inhibitory concentration: 49 nM
For compound 4 the middle estimate is 1.2-fold (0.09 log units) above the measured one, within the range that was stated.
By their numbers in this assay, from the lowest: compound 2; then compound 3; then compound 4; then compound 1.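

Replacing allyl with the far larger 3,7-dimethylocta-2,6-dien-1-yl in this assay gives only a 2.6-fold higher number from compound 3 to compound 4 (0.42 log units; beyond the scatter), so this place accepts a long branched chain at a modest cost relative to the allyl compound. Measured against the shortest chain shown, the cost is larger, at a 12-fold higher number from compound 2 to compound 4 (1.09 log units; beyond the scatter), and the order of the three compounds rises with chain size. Nothing given here explains these differences. From the compounds shown here alone, whether length, branching or the double bonds drive the rise stays open. A saturated chain of the same length, or a chain ending in an amine or a carboxylic acid, could help separate these.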